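The source may report more compounds than this note shows. Statements on the series, on what has been measured and on what is new or still open speak of the compounds shown alone.

Compound 2 `CCN(Cc1ccccc1Cl)C(=O)C1CCN(S(=O)(=O)c2ccc3cn[nH]c3c2)CC1` gives 93% in a functional assay on CHO cells for positive allosteric modulation of muscarinic acetylcholine receptor M5 (Homo sapiens), read by calcium flux; a lower number here means a smaller maximal response, a higher number a larger maximal response. Among the measured compounds shown here, the only other number comes from compound 1 `CCN(Cc1ccccc1)C(=O)C1CCN(S(=O)(=O)c2ccc3cn[nH]c3c2)CC1`, which gives 86% in this assay, and the step of a number 7 percentage points higher from compound 1 to compound 2 (within the scatter) lies within the scatter, so the two stand level. Compound 3 `CCN(Cc1ccccc1C(F)(F)F)C(=O)C1CCN(S(=O)(=O)c2ccc3cn[nH]c3c2)CC1` differs from compound 2 by trifluoromethyl in place of chloro on an aromatic carbon. For the measured compounds named here, the single measured step, a number 7 percentage points higher from compound 1 to compound 2 (within the scatter), concerns the same aromatic carbon and was small; no measurement speaks to a trifluoromethyl here. Compound 3 is therefore expected to show no step beyond the scatter, a number 1 percentage points lower from compound 2 to compound 3 (within the scatter). Compound 3 is estimated at 92%, in a range from 78% to 105%.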

Compound 3, largest response reached (reported as percent of maximum), in percent of the reference or control that the assay uses: 92%
The estimate for compound 3 equals the measured number at the digits printed; low and high end bracket the measured number.
By their numbers in this assay, from the lowest: compounds 1, 3 and 2 (each within the scatter of the next).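

In this assay, the step of a number 1 percentage points lower from compound 2 to compound 3 (within the scatter) shows that this aromatic carbon takes trifluoromethyl, with its four heavy atoms, as readily as chloro, with its one. The step of a number 6 percentage points higher from compound 1 to compound 3 (within the scatter) gives the same reading against hydrogen, so all three groups at this place stand level. As far as these compounds go, whether an amine or a carboxylic acid on this carbon would also hold the maximal response stays open, as does the effect of trifluoromethyl elsewhere on this ring. No evidence at hand offers a reason for the level numbers.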